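The source may report more compounds than this note shows. Statements on the series, on what has been measured and on what is new or still open speak of the compounds shown alone.

Working notes on the series in a functional assay on DU-145 cells (Homo sapiens) for cytotoxicity, read by MTT assay, with a stated time of 48 h; a lower number here means a stronger inhibitor, a higher number a weaker inhibitor. Compound 1 `COc1ccc(/C=C/C(=O)/C=C/c2cc3ccccc3nc2Cl)cc1` reads > 10000 nM, which is a limit. Compound 3 `COc1cc(OC)c(/C=C/C(=O)/C=C/c2cc3ccccc3nc2Cl)c(OC)c1` reads > 10000 nM, also a limit. Going by the values given here, compound 2 `COc1cc(OC)c(OC)cc1/C=C/C(=O)/C=C/c1cc2ccccc2nc1Cl` gives 3990 nM, the only actual number so far. Compound 4 `COc1cc(OC)c(OC)cc1/C=C/C(=O)/C=C/c1cc2ccccc2nc1Oc1ccccc1` carries phenoxy in place of chloro on an aromatic carbon. Among the compounds with values here, no measured pair tests this swap. With compound 2 at 3990 nM and the rest of the series showing (the limit of > 10000 nM in this assay, at which 2 of the 3 values shown sit), only a small shift toward weaker is expected in this assay, not clearly beyond the usual scatter. The expected change is a 1.3-fold higher number from compound 2 to compound 4 (0.10 log units; within the scatter). Compound 4 is estimated at 5000 nM, with an expected range of 1500 nM to 15000 nM.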

Compound 4, half-maximal inhibitory concentration: 9220 nM
The estimate for compound 4 lay 1.8-fold (0.27 log units) below the measured number, within the range that was stated.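

Going by these compounds alone, the position next to the ring nitrogen responds to this change, giving the first measured step: in this assay the swap gives a 2.3-fold higher number from compound 2 to compound 4 (0.36 log units; beyond the scatter) and counts as modest. Phenoxy in place of chloro still leaves a readable number, but moves it toward the weaker side. That number now lies close to the top of the readable range: the limit of > 10000 nM in this assay, at which 2 of the 4 values shown sit.

Going by these compounds, whether an amine at this position would give a lower number stays open. So does whether phenoxy has the same effect on the core of compound 1 or compound 3.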